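The source may report more compounds than this note shows. Statements on the series, on what has been measured and on what is new or still open speak of the compounds shown alone.

Measured so far:
compound 1 `O=C(O)c1ccc(NCc2cccc(Oc3ccccc3)c2)cc1` in a functional assay on CHO cells for agonist activity at Free fatty acid receptor 1 (Homo sapiens) (on this read-out lower numbers stand for an effect already at smaller amounts and higher numbers for an effect only at larger amounts of compound), reaches only the limit of the assay, < 10000 nM
compound 2 `O=C(O)/C=C/c1ccc(NCc2cccc(Oc3ccccc3)c2)cc1` in this assay gives 145 nM
compound 3 `O=C(O)COc1ccc(NCc2cccc(Oc3ccccc3)c2)cc1` in this assay gives 2040 nM

All three share one core and differ only in the acid-bearing group on the ring. Compound 3 stands at the highest number among the two that were read as numbers in this assay; its nearest neighbour is compound 2, and the step of a 14-fold higher number from compound 2 to compound 3 (1.15 log units; beyond the scatter) is large and beyond the scatter. Compound 1 gave only a limit, so the steps from it to the others cannot be sized; this is the evidence (the limit of < 10000 nM in this assay, at which 1 of the 3 values shown sits).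

Compound 4 `O=C(O)CSc1ccc(NCc2cccc(Oc3ccccc3)c2)cc1` is the next compound to consider. The change from compound 3 is (carboxymethyl)sulfanyl in place of carboxymethoxy on an aromatic carbon. Going by the values given here, none of the measured steps swaps one atom for another inside the acid-bearing chain while keeping its length: the only sized step, from compound 2 to compound 3, alters the whole linker. So no measured step bears directly on this change, and the expectation is a step of no size beyond the scatter in this assay, that is a 1.0-fold lower number from compound 3 to compound 4 (0.01 log units; within the scatter). The estimate for compound 4 is therefore 2000 nM, with a range from 700 nM to 6000 nM.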

Compound 4, half-maximal effective concentration: 324 nM
The estimate for compound 4 lay 6.2-fold (0.79 log units) above the measured number, outside the stated range (below it).
By their numbers in this assay, from the lowest: compound 2; then compound 4; then compound 3.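

In this assay, exchanging carboxymethoxy for (carboxymethyl)sulfanyl on this aromatic carbon gives a 6.3-fold lower number from compound 3 to compound 4 (0.80 log units; beyond the scatter), so the identity of a single atom in the chain matters at this position, even though both groups have the same counts of heavy atoms, hydrogen-bond donors and hydrogen-bond acceptors. Going by these compounds alone, the sulfur-linked chain recovers much of the distance to the 2-carboxyethenyl group but does not close it, with a 2.2-fold higher number from compound 2 to compound 4 (0.35 log units; beyond the scatter), and compound 2 therefore keeps the lowest number read so far. The steps from compound 1 to the other compounds cannot be read, since compound 1 gave only a limit: the limit of < 10000 nM in this assay, at which 1 of the 4 values shown sits.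

Within the data shown here, what the sulfur atom does to produce this step stays open, as the numbers show only that the exchange changes the read-out and give no reason for it. It also remains to be seen how a carboxymethylamino group or a saturated 2-carboxyethyl chain would compare at the same position, and whether a longer chain carrying the sulfur would move the number further in either direction.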